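Ether in place of ester on a quinone side chain

The compounds below may be only part of what the source reports. "The series", "measured", "known", "first", "only" and "open" are said of these compounds alone.

Three compounds have been measured in a functional assay on HeLa cells (Homo sapiens) for cytotoxicity, read by MTT assay; a higher number here means a weaker inhibitor, a lower number a stronger inhibitor:
Compound 1 `CC(C)=CC[C@@H](OC(=O)CCO)C1=CC(=O)c2c(O)ccc(O)c2C1=O` gives 67600 nM.
Compound 2 `CCCC(O)CC(=O)O[C@H](CC=C(C)C)C1=CC(=O)c2c(O)ccc(O)c2C1=O` gives 59300 nM.
Compound 3 `CCCCC(CC(=O)O[C@H](CC=C(C)C)C1=CC(=O)c2c(O)ccc(O)c2C1=O)OC(C)=O` gives 73500 nM.

All three share the same core and differ only in the group attached through the oxygen on the side chain. The number for compound 2 sits together with those of compounds 1 and 3: the three values lie within the usual scatter of one another, so none can be called stronger or weaker than the rest.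

Compound 4 `CCC(CO[C@H](CC=C(C)C)C1=CC(=O)c2c(O)ccc(O)c2C1=O)OC(C)=O` has not yet been measured. Compared with compound 2, its change is 2-acetoxybutyl in place of (2-hydroxypentyl)carbonyl on an oxygen on a saturated carbon.

The measured steps all bear on this region of the molecule, and each of them is small: a 1.1-fold lower number from compound 1 to compound 2 (0.06 log units; within the scatter), a 1.1-fold higher number from compound 1 to compound 3 (0.04 log units; within the scatter) and a 1.2-fold higher number from compound 2 to compound 3 (0.09 log units; within the scatter). Since changes of this kind, including adding an acetoxy group, have left the number essentially unmoved, the expectation for compound 4 is no step beyond the scatter, in either direction.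

Compound 4 is therefore expected to give 62000 nM in this assay, with a range from 25000 nM to 150000 nM, which means the step of a 1.0-fold higher number from compound 2 to compound 4 (0.02 log units; within the scatter) is estimated to be small.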

Compound 4, half-maximal inhibitory concentration: 44000 nM
Beside the measured number, compound 4's estimate is 1.4-fold (0.15 log units) above it; measured number inside the range.
By their numbers in this assay, from the lowest: compounds 4, 2, 1 and 3 (each within the scatter of the next).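

In this assay, putting 2-acetoxybutyl in place of (2-hydroxypentyl)carbonyl on the oxygen on a saturated carbon uses the same atoms, joined differently, and turns the ester link into an ether, with a 1.3-fold lower number from compound 2 to compound 4 (0.13 log units; within the scatter) as the outcome. Starting from the shorter (2-hydroxyethyl)carbonyl group, the same kind of swap gives a 1.5-fold lower number from compound 1 to compound 4 (0.19 log units; within the scatter) as its outcome, so neither step can be told apart from repeated measurement of one compound. The earlier compounds all carried a carbonyl on this oxygen and varied only the chain beyond it, whereas compound 4 shows that, among these four compounds, removing that carbonyl from the oxygen still leaves the number in the same range.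

As far as these compounds go, compound 4 changes the link and replaces the free hydroxyl with an acetoxy group in one move, so the effect of each alone stays open, as does what a 2-hydroxybutyl group, an amine, a carboxylic acid or a much longer chain on this ether oxygen would give. No independent measurement is available to explain why the number stays so unmoved at this position.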